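The source may hold more compounds than are shown below. What is called first, only, known or untested is meant among the compounds shown, and "the series" means these compounds.

Measured so far:
- Compound 1 `Sc1nnc(-c2ccc3c(c2)OCCO3)n1-c1ccccc1`: 51900 nM
- Compound 2 `O=[N+]([O-])c1cccc(CSc2nnc(-c3ccc4c(c3)OCCO4)n2-c2ccccc2)c1`: 45200 nM
- Compound 3 `COc1cccc(CSc2nnc(-c3ccc4c(c3)OCCO4)n2-c2ccccc2)c1`: > 100000 nM

These values come from a functional assay on HeLa cells (Homo sapiens) for antiproliferative activity, read by MTT assay, with a stated time of 24 h; a lower number here means a stronger inhibitor, a higher number a weaker inhibitor. Compound 3 gives only a limit of the assay, not a number: > 100000 nM. Compound 4 `Cc1ccccc1CSc1nnc(-c2ccc3c(c2)OCCO3)n1-c1ccccc1` carries 2-methylphenyl in place of 3-methoxyphenyl on a saturated chain carbon bound to a sulfur. Among the compounds with values here, three measured steps bear on this change. Replacing the hydrogen on sulfur gives a 1.1-fold lower number from compound 1 to compound 2 (0.06 log units; within the scatter) with 3-nitrobenzyl and an at least 1.9-fold higher number from compound 1 to compound 3 (0.28 log units; that floor lies within the scatter) with 3-methoxybenzyl. Putting methoxy in place of nitro gives an at least 2.2-fold higher number from compound 2 to compound 3 (0.34 log units; beyond the scatter). Compound 4 has neither group, so its number is expected to fall near that of compound 2 at 45200 nM. The expected change is an at least 1.6-fold lower number from compound 3 to compound 4 (0.22 log units; that floor lies within the scatter). For compound 4 the estimate is 60000 nM, with an expected range of 28000 nM to 100000 nM.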

Compound 4, half-maximal inhibitory concentration: 36000 nM
Beside the measured number, compound 4's estimate is 1.7-fold (0.22 log units) above it; low and high end bracket the measured number.
By their numbers in this assay, from the lowest: compounds 4, 2 and 1 (each within the scatter of the next). At a limit, above all of these: compound 3.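

At this position, on a saturated chain carbon bound to a sulfur, 2-methylphenyl in place of 3-methoxyphenyl gives an at least 2.7-fold lower number from compound 3 to compound 4 (0.44 log units; beyond the scatter), so a substituted benzyl group on sulfur does not always push the number up. That step is only a floor, as compound 3 gives a limit and not a number: the limit of > 100000 nM in this assay, at which 1 of the 4 values shown sits. The other steps, a 1.3-fold lower number from compound 2 to compound 4 (0.10 log units; within the scatter) and a 1.4-fold lower number from compound 1 to compound 4 (0.16 log units; within the scatter), show that the benzyl groups with a measured number have not clearly moved it from that of the parent with hydrogen on sulfur.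

Still open, as far as these compounds go, is what a benzyl ring carrying an amine or a carboxylic acid would give, and what a longer chain between the sulfur and the ring would do.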